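Changing the group on the carbonyl carbon of compound 2

The source may report more compounds than this note shows. Statements on the series, on what has been measured and on what is new or still open speak of the compounds shown alone.

Compound 1 `O=C(/C=C/c1ccc(Br)cc1)Oc1ccc(/C=C2\CCCCC2=O)cc1` gives 131000 nM
Compound 2 `CN(C)CC1CCC/C(=C\c2ccc(OC(=O)/C=C/c3ccc(Br)cc3)cc2)C1=O` gives 4440 nM

Both values come from a functional assay on CCRF-CEM cells (Homo sapiens); on this read-out higher numbers stand for weaker inhibition and lower numbers for stronger inhibition. Compound 2 holds the lower of the two numbers, so it is the stronger inhibitor of this pair. Among the measured compounds shown here, the only measured step, a 30-fold lower number from compound 1 to compound 2 (1.47 log units; beyond the scatter), is large and came with (dimethylamino)methyl in place of hydrogen on a saturated ring carbon. Compound 3 `COc1ccc(C(=O)Oc2ccc(/C=C3\CCCC(CN(C)C)C3=O)cc2)cc1` keeps that group and differs elsewhere: 4-methoxyphenyl in place of 2-(4-bromophenyl)ethenyl on a carbonyl carbon, with 4-methoxyphenyl in place of 2-(4-bromophenyl)ethenyl on a carbonyl carbon. For the measured compounds named here, no measured step touches this place, so the data give no sign of a direction or size for the change. With nothing pointing to a shift, none beyond the scatter is expected in this assay, and the estimated change is a 1.1-fold higher number from compound 2 to compound 3 (0.05 log units; within the scatter). For compound 3 the expected value is 5000 nM, within an estimated range from 1700 nM to 15000 nM.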

Compound 3, half-maximal inhibitory concentration: 5070 nM
The estimate for compound 3 lay 1.0-fold (0.01 log units) below the measured number; the range from low to high includes it.
By their numbers in this assay, from the lowest: compounds 2 and 3 (each within the scatter of the next); then compound 1.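

In this assay, the change to 4-methoxyphenyl in place of 2-(4-bromophenyl)ethenyl on a carbonyl carbon gives a 1.1-fold higher number from compound 2 to compound 3 (0.06 log units; within the scatter) and so does not register in this read-out. Among the compounds shown here, this is the first look at this position, and it shows that the two groups can be exchanged here without a step beyond the scatter, even though the entering group has no double bond outside its aromatic ring and no bromine, and brings an oxygen that counts as a hydrogen-bond acceptor. No measurement offered here explains why the two groups read alike.

Both groups carry a six-membered aromatic ring of carbon only, so the result says nothing about a group without one, such as a plain ethyl or cyclohexyl. As far as these compounds go, how a charged or hydrogen-bond-donating substituent on that ring, such as a carboxylic acid or an amine, would read also stays open.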